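This account rests on a few compounds, and the source may have more. Where it says the series, first, only, none or still open, it means among the compounds named here.

Compounds measured so far:

Compound 1, `O=C1N=C(N2N=C(c3ccccc3)CC2c2ccccc2O)S/C1=C1/C(=O)Nc2ccccc21`, gives 4220 nM in a functional assay on cells (Cancer cell lines, Homo sapiens) for cytotoxicity, read by sulforhodamine B assay, with a stated time of 48 h; a higher number here means a weaker inhibitor of growth, a lower number a stronger inhibitor of growth.
Compound 2, `COc1ccc(C2CC(c3ccccc3)=NN2C2=NC(=O)/C(=C3\C(=O)Nc4ccccc43)S2)cc1`, gives 4390 nM in this assay.
Compound 3, `COc1ccc(C2CC(c3ccc4ccccc4c3)=NN2C2=NC(=O)/C(=C3\C(=O)Nc4ccccc43)S2)cc1`, gives 12400 nM in this assay.

Compound 2 stands second highest of the three numbers. Compound 1 sits closest to it, and their two values lie within the scatter of each other, so nothing separates them. Compound 3 sits furthest away, with a 2.8-fold higher number from compound 2 to compound 3 (0.45 log units; beyond the scatter), a modest step beyond the scatter.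

Compound 4, `O=C1N=C(N2N=C(c3ccccc3)CC2c2ccc(Cl)cc2)S/C1=C1/C(=O)Nc2ccccc21`, has not yet been measured. It differs from compound 2 in one place: chloro in place of methoxy on an aromatic carbon. Of the two measured steps, only one touches the same part of the shared core, the ring on the saturated ring carbon. That step, a 1.0-fold higher number from compound 1 to compound 2 (0.02 log units; within the scatter), was within the scatter, which suggests this ring accepts a change in its substituent without a shift in this assay. Within the data shown here, no measured step involves a chloro group at all. The other step, a 2.8-fold higher number from compound 2 to compound 3 (0.45 log units; beyond the scatter), concerns a different ring and does not bear on this change.

On this basis, compound 4 is expected to show a 1.0-fold higher number from compound 2 to compound 4 (0.01 log units; within the scatter), a step that lies within the scatter rather than beyond it. The value for compound 4 is therefore estimated at 4500 nM, with a range from 2000 nM to 10000 nM.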

Compound 4, concentration for total growth inhibition: 390 nM
Compound 4: the middle estimate sits 12-fold (1.06 log units) above what was measured, outside the stated range (below it).
By their numbers in this assay, from the lowest: compound 4; then compounds 1 and 2 (each within the scatter of the next); then compound 3.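

Among these compounds, the ring on the saturated ring carbon turns out not to be indifferent to its substituent in this assay: the earlier step, a 1.0-fold higher number from compound 1 to compound 2 (0.02 log units; within the scatter), had suggested it was, but that step compared only two oxygen-bearing groups. Chloro in place of methoxy, para to a large group, gives an 11-fold lower number from compound 2 to compound 4 (1.05 log units; beyond the scatter), a large step from a small exchange of groups on the same ring. Against the 2-hydroxyphenyl group the picture is the same, with an 11-fold lower number from compound 1 to compound 4 (1.03 log units; beyond the scatter), so 4-chlorophenyl stands apart from both oxygen-bearing rings, which themselves lie within the scatter of each other. Nothing given here explains this difference.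

The compounds shown leave open whether the gain belongs to chloro itself or would also appear with a bromo, methyl or trifluoromethyl group in that place, and whether chloro elsewhere on the ring would do the same. They also leave open whether 4-chlorophenyl would bring a similar gain when the phenyl on the carbon with a double bond to nitrogen is replaced by naphthalen-2-yl, as in compound 3.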